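Sulfonyl substituent variation on the shared tetrahydropyridinyl-indole core

The compounds below may be only part of what the source reports. "The series", "measured", "known", "first", "only" and "open" are said of these compounds alone.

Measured so far:
compound 1 `COc1ccc(S(=O)(=O)n2cc(C3=CCNCC3)c3ccccc32)cc1` 18 nM
compound 2 `O=S(=O)(c1nccc2sncc12)n1cc(C2=CCNCC2)c2ccccc21` 5 nM

Both compounds were characterised in an assay on HeLa cells for binding affinity to 5-hydroxytryptamine receptor 6 (Homo sapiens); on this read-out lower numbers stand for stronger inhibition and higher numbers for weaker inhibition. On these two numbers compound 2 stands lowest; compound 1 is nearest, with a 3.6-fold lower number from compound 1 to compound 2 (0.56 log units; beyond the scatter) separating the two.

Compound 3 `CCCCS(=O)(=O)n1cc(C2=CCNCC2)c2ccccc21` is not yet measured. Compared with compound 2 it carries a group of 4 heavy atoms (4 carbon; no ring) in place of a group of 9 heavy atoms (6 carbon, 2 nitrogen, 1 sulfur; one five-membered aromatic ring with 2 hetero atoms, one six-membered aromatic ring with 1 hetero atom), on a sulfonyl sulfur. Among the measured compounds shown here, the only measured step, from compound 1 to compound 2, also sits on this sulfonyl sulfur, but it exchanges one ring group for another and was modest in size; no measured step removes the ring groups altogether or introduces a chain there. The new change is therefore not covered directly by the data in hand, and the estimate below is an extrapolation resting only on the fact that both measured compounds keep a ring on the sulfonyl sulfur. Compound 3 is expected to show a 12-fold higher number from compound 2 to compound 3 (1.08 log units; beyond the scatter) in this assay, beyond the scatter and towards weaker inhibition. Compound 3 is estimated at 60 nM, with a range of 15 nM to 300 nM.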

Compound 3, inhibition constant: 77 nM
For compound 3 the middle estimate is 1.3-fold (0.11 log units) below the measured one, and the stated range covers the measured number.
By their numbers in this assay, from the lowest: compound 2; then compound 1; then compound 3.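

Among the compounds shown here, on the sulfonyl sulfur, butyl is the first group without a ring, and in this assay it brings the largest step so far, a 15-fold higher number from compound 2 to compound 3 (1.19 log units; beyond the scatter), against the fused bicyclic group. The step against 4-methoxyphenyl, a 4.3-fold higher number from compound 1 to compound 3 (0.63 log units; beyond the scatter), is also beyond the scatter, so both ring-bearing compounds give lower numbers than the butyl compound, and the size of the loss depends on which ring group it is read against. No measured property of these groups is available to account for these steps.

From the compounds shown here alone, whether the loss comes with the absence of a ring or with butyl itself stays open; methyl, a longer chain or benzyl on the sulfonyl sulfur would separate the two. Also open, going by these compounds, is how an amine or a carboxylic acid at the end of such a chain would read.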